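Notes on adding a hydroxy group to compound 3

The source may hold more compounds than are shown below. What is called first, only, known or untested is meant among the compounds shown, and "the series" means these compounds.

- compound 1 `O=[N+]([O-])c1ccc(O)c(/C=N/Nc2ncccn2)c1` gives 23800 nM as its value
- compound 2 `C(=N/Nc1ncccn1)\c1ccccn1` gives 24600 nM as its value
- compound 3 `O=C(N/N=C/c1ccccc1O)c1ncccn1` gives > 150000 nM as a limit

Compound 3 stands at the limit of > 150000 nM in this assay, at which 1 of the 3 values shown sits, and so has only a limit as its reading in an ADME assay on cells (Peritoneal macrophage, Mus musculus, strain BALB/c) for cytotoxicity, with a stated time of 72 h (on this read-out lower numbers stand for higher toxicity in this test and higher numbers for lower toxicity in this test), on these macrophages. Compound 1 and compound 2 lie within the usual scatter of each other, and both carry numbers. The step to compound 4 `O=C(N/N=C/c1cccc(O)c1O)c1ncccn1` puts hydroxy in place of hydrogen on an aromatic carbon, ortho to a hydroxy group and meta to a large group. Among the measured compounds shown here, no two measured compounds differ in one place, so this change has no direct guide. A moderate move toward lower numbers in this assay is expected, with compound 1 at 23800 nM as the reference for the low side of the range. The estimated change is an at least 2.1-fold lower number from compound 3 to compound 4 (0.33 log units; beyond the scatter) and the reading may still stop at the limit. In this assay the expected value for compound 4 is 70000 nM (estimated range 20000 nM to 150000 nM).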

Compound 4, half-maximal cytotoxic concentration: > 150000 nM
Compound 4 ended at the assay's limit; the forecaster's own chance of this, stated with the estimate: 35%; middle value at least 2.1-fold (0.33 log units) away from the limit.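

Compound 3 and compound 4 both stop at a limit, so no step between them can be read in this assay: the limit of > 150000 nM in this assay, at which 2 of the 4 values shown sit.

The compounds shown leave open whether hydroxy in place of hydrogen on this aromatic carbon changes the half-maximal cytotoxic concentration at all, and in which direction.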